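Semicarbazone series: phenol-methoxy aryl in place of difluorophenyl

The source may hold more compounds than are shown below. What is called first, only, known or untested is meant among the compounds shown, and "the series" means these compounds.

Two members of the series have been run in a functional assay on U-87MG ATCC cells (Homo sapiens) for cytotoxicity, read by MTT assay, with a stated time of 72 h; on this read-out lower numbers stand for stronger inhibition and higher numbers for weaker inhibition. Compound 1, `CN(C)CCn1cnnc1-c1cc(Oc2ccc(NC(=O)N/N=C/c3cc(C(C)(C)C)cc(C(C)(C)C)c3O)cc2F)ccn1`, gives 520 nM in this assay. Compound 2, `CN(C)CCn1cnnc1-c1cc(Oc2ccc(NC(=O)N/N=C/c3ccc(F)cc3F)cc2F)ccn1`, gives 1900 nM in this assay, the highest of the two numbers; the gap to compound 1 lies beyond the usual scatter. Compound 3, `COc1ccc(/C=N/NC(=O)Nc2ccc(Oc3ccnc(-c4nncn4CCN(C)C)c3)c(F)c2)cc1O`, has not yet been run. The change from compound 2 to compound 3 is 3-hydroxy-4-methoxyphenyl in place of 2,4-difluorophenyl on a carbon with a double bond to nitrogen. Among the compounds with values here, compound 1 shows that an aryl ring carrying a hydroxyl group is compatible with a lower number than compound 2, but no other pair isolates this kind of change, so the direction is uncertain. A moderate drop in the number is expected, as a 1.9-fold lower number from compound 2 to compound 3 (0.28 log units; within the scatter). Compound 3 is accordingly expected to give about 1000 nM in this assay, within a range from 300 nM to 3500 nM.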

Compound 3, half-maximal inhibitory concentration: > 100000 nM
Compound 3: no number, only a limit (the forecaster's own chance of this, stated with the estimate: 5%); at least 100-fold (2.00 log units) between middle value and limit.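

On a carbon with a double bond to nitrogen, the aryl group has a large influence in this assay: 3-hydroxy-4-methoxyphenyl in place of 2,4-difluorophenyl gives an at least 52-fold higher number from compound 2 to compound 3 (1.72 log units; beyond the scatter). This step is a lower bound, as the value for compound 3 is a limit of the assay and not a number: the limit of > 100000 nM in this assay, at which 1 of the 3 values shown sits.

A hydroxyl on the aryl ring does not by itself go with this loss, as compound 1, which also carries one, gives 520 nM.

The compounds shown leave open whether the step follows the hydroxyl, the methoxy or the pair together, and 4-methoxyphenyl or 3-hydroxyphenyl at this place would separate them. On these data alone, how far the number for compound 3 lies past the limit also remains open.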